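The source may hold more compounds than are shown below. What is called first, only, known or untested is meant among the compounds shown, and "the series" means these compounds.

Measured in a physicochemical assay for lipophilicity, measured as octanol-water partition; a higher number here means a more lipophilic compound, a lower number a more polar compound:
- compound 1 `CC(C)[C@@H]1CC[C@@H](C)C[C@H]1OC(=O)/C=C/c1cccc([N+](=O)[O-])c1`: 5.18
- compound 2 `CCC(=O)O[C@@H]1C[C@H](C)CC[C@H]1C(C)C`: 3.54
- compound 3 `CC(C)[C@@H]1CC[C@@H](C)C[C@H]1OC(=O)CCl`: 3.5

Compound 3 stands within the scatter of compound 2 and well under compound 1. Compound 4 `CC(Cl)C(=O)O[C@@H]1C[C@H](C)CC[C@H]1C(C)C` differs from compound 3 by methyl in place of hydrogen on a saturated chain carbon bound to a carbonyl carbon and a chlorine atom. For the measured compounds named here, the nearest measured step, a number 0.04 log units lower from compound 2 to compound 3 (within the scatter), exchanges methyl for chloro, so it does not measure this gain of methyl, and no measured step does. With methyl entering and only hydrogen leaving, a modest rise is expected, an estimated a number 0.40 log units higher from compound 3 to compound 4 (beyond the scatter). For compound 4 the estimate is 3.9, with an expected range of 3.6 to 4.25.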

Compound 4, partition coefficient: 4.04
Compound 4: the middle estimate sits 0.14 log units below what was measured; the range from low to high includes it.
By their numbers in this assay, from the lowest: compounds 3 and 2 (each within the scatter of the next); then compound 4; then compound 1.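

In this assay, this chain carbon now responds to additions: methyl in place of hydrogen on the carbon bound to a carbonyl carbon and a chlorine atom gives a number 0.54 log units higher from compound 3 to compound 4 (beyond the scatter), and chloro in place of hydrogen on the carbon bound to a carbonyl carbon and a saturated chain carbon gives a number 0.50 log units higher from compound 2 to compound 4 (beyond the scatter). The earlier exchange of methyl for chloro, by contrast, stayed within the scatter, so adding a group here registers where swapping one did not. Nothing available accounts for these steps.

As far as these compounds go, whether a longer chain or an amine at this carbon would give a similar step remains open. So does whether a fluorine atom in place of the chlorine atom would.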